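Shortening the chain on the aromatic nitrogen: working notes

The source may hold more compounds than are shown below. What is called first, only, known or untested is meant among the compounds shown, and "the series" means these compounds.

Measured so far:
Compound 1 `CCn1c(/C=C2/C(=O)Nc3ccc(F)cc32)nc2ccccc21`: > 50000 nM, a limit of the assay and not a number.
Compound 2 `CC(C)n1c(/C=C2/C(=O)Nc3ccc(F)cc32)nc2ccccc21`: 22700 nM.
Compound 3 `CCn1c(/C=C2/C(=O)Nc3ccc(Br)cc32)nc2ccccc21`: "not determined" (no result reported).

In a functional assay on MDA-MB-231 cells (Homo sapiens) for cytotoxicity, read by MTT assay, with a stated time of 48 h (a higher number here means a weaker inhibitor, a lower number a stronger inhibitor), compound 2 gives 22700 nM. For compound 1 the result in this assay is only a limit, > 50000 nM; the relevant point is the limit of > 50000 nM in this assay, at which 1 of the 3 values shown sits. The step of an at least 2.2-fold higher number from compound 2 to compound 1 (0.34 log units; beyond the scatter) goes with the change (hydrogen in place of methyl on a saturated chain carbon bound to an aromatic nitrogen and a saturated chain carbon). Compound 3 has a different core from compound 2; the difference between the two cores is not broken down here, and compound 3 has no result in this assay. Compound 4 `Cn1c(/C=C2/C(=O)Nc3ccc(Br)cc32)nc2ccccc21` stands to compound 3 through (hydrogen in place of methyl on a saturated chain carbon bound to an aromatic nitrogen). This is the same kind of change as the measured one, not the same: there the carbon is bound to an aromatic nitrogen and a saturated chain carbon, here only to an aromatic nitrogen. The change occurs twice among the compounds shown. The expected direction for compound 4 rests on compound 1 and compound 2, through an at least 2.2-fold higher number from compound 2 to compound 1 (0.34 log units; beyond the scatter), pointing to a weaker compound; with compound 3 unmeasured the anchor is loose. Compound 4 is expected near 60000 nM, estimated between 15000 nM and 200000 nM.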

Compound 4, half-maximal inhibitory concentration: > 50000 nM
Compound 4: only a limit was reported; the forecaster's own chance of this, stated with the estimate: 60%; the middle value does not contradict the limit.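

In this assay compound 4 gives > 50000 nM, a limit of the assay and not a number. Within the data shown here, compound 3 stands at "not determined" (no result reported), so no step from compound 3 to compound 4 can be read. The compounds shown leave open whether going from ethyl to methyl moves the value on this core, and how this core compares with that of compound 1.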